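The source may report more compounds than this note shows. Statements on the series, on what has been measured and on what is new or still open speak of the compounds shown alone.

The measured compounds in this set are:

compound 1, `CC[C@H]1CC[C@H](c2ccc(NC(=S)Nc3cccc(C(F)(F)F)c3)cc2)CC1`, 39000 nM
compound 2, `FC(F)(F)c1cccc(NC(=S)Nc2ccc(Cl)cc2)c1`, 6800 nM
compound 3, `CCCCc1ccc(NC(=S)Nc2cccc(C(F)(F)F)c2)c(C)c1`, 43000 nM

In an ADME assay on MT4 cells (Homo sapiens) for cytotoxicity (a lower number here means that less compound is tolerated, a higher number that more compound is tolerated), compound 2 gives 6800 nM, the lowest of the three numbers, so it is the least well tolerated compound here. Compound 1 gives 39000 nM and compound 3 gives 43000 nM, and both of these stand beyond the scatter above compound 2. Among the compounds with values here, the only step between measured compounds that differ in one place is a 5.7-fold lower number from compound 1 to compound 2 (0.76 log units; beyond the scatter), which describes a change on an aromatic carbon. Within the data shown here, compound 3 shares no single-point step with compound 2; their two values simply show compound 3 at the higher number.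

Compound 4, `FC(F)(F)c1cccc(NC(=S)NCc2ccco2)c1`, differs from compound 2 in one place: (furan-2-yl)methyl in place of 4-chlorophenyl on an amide-type nitrogen. Among the measured compounds shown here, no measured step touches the group on the amide-type nitrogen, so none of the steps bears directly on this change. The one step shown, a 5.7-fold lower number from compound 1 to compound 2 (0.76 log units; beyond the scatter), tells only that compound 2 sits at the low end of the series and that its neighbours with other substituents lie higher, beyond the scatter. On that basis a modest move upward in this assay is expected, without a firm anchor. Compound 4 is therefore estimated at 20000 nM, with a range from 6000 nM to 60000 nM, meaning an expected step of a 2.9-fold higher number from compound 2 to compound 4 (0.47 log units; beyond the scatter).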

Compound 4, half-maximal cytotoxic concentration: 43000 nM
The estimate for compound 4 lay 2.2-fold (0.33 log units) below the measured number, and the stated range covers the measured number.
By their numbers in this assay, from the lowest: compound 2; then compounds 1, 3 and 4 (each within the scatter of the next).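

In this assay, the amide-type nitrogen proves to be a second place where a single change moves the number beyond the scatter: (furan-2-yl)methyl in place of 4-chlorophenyl gives a 6.3-fold higher number from compound 2 to compound 4 (0.80 log units; beyond the scatter). Within the data shown here, the one earlier step concerned a change on an aromatic carbon, whereas this one replaces the whole group on the nitrogen, exchanging a six-membered aromatic ring of carbon only for a five-membered aromatic ring with 1 hetero atom, and adding 1 hydrogen-bond acceptor. Nothing measured here explains why the number rises with this exchange.

The compounds shown do not separate the parts of the exchange, so the higher number cannot yet be assigned to the loss of the chlorine, the change of ring, or the methyl link between the ring and the nitrogen. On these data alone, a benzyl or a 4-chlorobenzyl group on the same nitrogen, or a thiophen-2-ylmethyl group in place of the (furan-2-yl)methyl, would help to pull these parts apart, and the effect of any such group on this number remains open.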